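The source may hold more compounds than are shown below. What is called first, only, known or untested is meant among the compounds shown, and "the series" means these compounds.

In a functional assay on CHO-K1 cells for antagonist activity at transient receptor potential cation channel subfamily V member 1 (Homo sapiens), read by FLIPR (a lower number here means a stronger inhibitor, a higher number a weaker inhibitor), compound 1, `CC(C(=O)NCc1ccc(C(F)(F)F)nc1Nc1ccccc1)c1ccc(NS(C)(=O)=O)c(F)c1`, gives 1400 nM. Among the three measured compounds this is the highest number. Compound 2, `Cc1ccc(Cl)cc1Nc1nc(C(F)(F)F)ccc1CNC(=O)C(C)c1ccc(NS(C)(=O)=O)c(F)c1`, gives 140 nM in this assay, and compound 3, `CC(C(=O)NCc1ccc(C(F)(F)F)nc1N1CCC2(CC1)CC(c1ccccc1)=NO2)c1ccc(NS(C)(=O)=O)c(F)c1`, gives 289 nM. Going by the values given here, the single step recorded between measured compounds is a 10-fold lower number from compound 1 to compound 2 (1.00 log units; beyond the scatter); it changes the substituents on the anilino group while keeping the anilino nitrogen in place. Compound 4, `CC(C(=O)NCc1ccc(C(F)(F)F)nc1N1CCCCCC1)c1ccc(NS(C)(=O)=O)c(F)c1`, differs from compound 1 in a different way: azepan-1-yl in place of anilino on an aromatic carbon. Among the compounds with values here, no recorded step covers this exact replacement. Within the data shown here, the comparison of compound 1 with compound 3 shows only that a non-aromatic amine-linked ring system in place of the anilino group went with a lower number, but that ring system carries much more than azepan-1-yl does, so the bearing on compound 4 is loose. Among the measured compounds shown here, with one supporting comparison and no direct precedent, a moderate drop is expected rather than a large one, and a result within the scatter of compound 1 cannot be excluded. The author therefore estimates for compound 4 a value of 700 nM in this assay, within a range of 250 nM to 2500 nM, which corresponds to an expected step of a 2.0-fold lower number from compound 1 to compound 4 (0.30 log units; within the scatter).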

Compound 4, half-maximal inhibitory concentration: 25.1 nM
The estimate for compound 4 lay 28-fold (1.45 log units) above the measured number; measured number below the stated range.
By their numbers in this assay, from the lowest: compound 4; then compound 2; then compound 3; then compound 1.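

In this assay, azepan-1-yl in place of anilino on the aromatic carbon next to the ring nitrogen gives a 56-fold lower number from compound 1 to compound 4 (1.75 log units; beyond the scatter), a larger step than a 10-fold lower number from compound 1 to compound 2 (1.00 log units; beyond the scatter) obtained by adding substituents to the anilino ring. The two groups have the same heavy-atom count, so at this position the lower number goes with a seven-membered non-aromatic ring that has no hydrogen-bond donor, and neither the aromatic ring nor the anilino hydrogen is needed for it. The unsubstituted azepane also outdoes the substituted anilino group, with a 5.6-fold lower number from compound 2 to compound 4 (0.75 log units; beyond the scatter), yet nothing available explains why this replacement has so large an effect.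

The compounds shown leave open whether the seven-membered ring itself matters or whether a pyrrolidin-1-yl, piperidin-1-yl or morpholin-4-yl group would serve as well. They also do not separate the loss of the anilino hydrogen from the loss of the aromatic ring, a question that a methyl group on the anilino nitrogen could address, and they do not show whether a methyl or chloro substituent on the azepane would lower the number further.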